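Swapping Chloro for Bromo on a Shared Core

A few compounds are considered here, and "the series" means these few. Any claim that something is new, unique, unknown or untested is made for them only; others in the source may bear on it.

For the measured compounds named here, compound 2 `CC(C)n1nc(-c2ccc3oc(N)nc3c2)c2c(Cl)nc(N)nc21` holds the only number in an ADME assay on cells (Hepatocyte, Homo sapiens) for metabolic stability, read by LC-MS, with a stated time of 90 min, tested at 1 uM (a lower number here means slower removal, a higher number faster removal of the compound), giving 11 uL/min. Compound 1 `CC(C)n1nc(-c2ccc3oc(N)nc3c2)c2c(CO)nc(N)nc21` reaches only a limit of this assay there, < 5 uL/min. Going by the values given here, the one measured step, an at least 2.2-fold higher number from compound 1 to compound 2 (0.34 log units; beyond the scatter), starts from that limit of < 5 uL/min in this assay, at which 1 of the 2 values shown sits, and exchanges a hydroxymethyl for a halogen rather than one halogen for another. Compound 3 `CC(C)n1nc(-c2ccc3oc(N)nc3c2)c2c(Br)nc(N)nc21` differs by bromo in place of chloro on an aromatic carbon. Among the compounds with values here, with no measured halogen-for-halogen step to lean on, for compound 3 the expected change is small, a 1.2-fold higher number from compound 2 to compound 3 (0.07 log units; within the scatter). Compound 3 is therefore estimated at 13 uL/min, between 6 uL/min and 28 uL/min.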

Compound 3, intrinsic clearance in a liver preparation (reported as CLH), per the amount of preparation that the assay uses: 55 uL/min
The estimate for compound 3 lay 4.2-fold (0.63 log units) below the measured number; the whole stated range lies below it.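

In this assay, the position next to the ring nitrogen proves sensitive even to a swap between two halogens: a 5.0-fold higher number from compound 2 to compound 3 (0.70 log units; beyond the scatter). Measured against hydroxymethyl, the change at the same aromatic carbon is larger still, an at least 11-fold higher number from compound 1 to compound 3 (1.04 log units; beyond the scatter). That step starts from a limit rather than a number, the one held by compound 1: the limit of < 5 uL/min in this assay, at which 1 of the 3 values shown sits.

The compounds shown leave open how an iodo, a methyl or a nitrile would read at this place, and whether an amine would stay nearer hydroxymethyl or the halogens. They also give no reason why bromo and chloro part so clearly here.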